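This account rests on a few compounds, and the source may have more. Where it says the series, first, only, none or still open, it means among the compounds named here.

Going by the values given here, in a functional assay on OCI-Ly3 cells (Homo sapiens) for antiproliferative activity (on this read-out higher numbers stand for an effect only at larger amounts of compound and lower numbers for an effect already at smaller amounts), compound 2 (`CCOC(C)c1c(NC(=O)Nc2cnc(-n3nccn3)c(Cl)c2)cnc2ccc(F)cc12`) gives 590 nM as the lower of the two numbers so far, and compound 1 (`COC(C)(C)c1c(NC(=O)Nc2cnc(-n3nccn3)c(Cl)c2)cnc2ccccc12`) gives 4430 nM as the higher, a gap beyond the scatter. Compound 3 (`COC(C)(C)c1c(NC(=O)Nc2cnc(-n3nccn3)c(Cl)c2)cnc2ccc(F)cc12`) carries 1-methoxy-1-methylethyl in place of the 1-ethoxyethyl of compound 2 on an aromatic carbon (1-methoxy-1-methylethyl in place of 1-ethoxyethyl on an aromatic carbon) and has the same atoms, joined differently. Among the compounds with values here, no measured step isolates this change. Within the data shown here, compound 1 also carries 1-methoxy-1-methylethyl and stands at 4430 nM in this assay as the only guide. A rise beyond the scatter is therefore expected, estimated as a 2.5-fold higher number from compound 2 to compound 3 (0.41 log units; beyond the scatter) in size. In this assay compound 3 is estimated at 1500 nM with 500 nM to 4500 nM as the expected range.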

Compound 3, half-maximal effective concentration: 410 nM
For compound 3 the middle estimate is 3.7-fold (0.56 log units) above the measured one; the whole stated range lies above it.
By their numbers in this assay, from the lowest: compounds 3 and 2 (each within the scatter of the next); then compound 1.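

In this assay, 1-methoxy-1-methylethyl and 1-ethoxyethyl cannot be told apart on this aromatic carbon opposite the ring nitrogen, with a 1.4-fold lower number from compound 2 to compound 3 (0.16 log units; within the scatter). The one-place change that does register is fluoro in place of hydrogen, a large step with an 11-fold lower number from compound 1 to compound 3 (1.03 log units; beyond the scatter). No available evidence bears on the cause of either step. On these data alone, what remains open is whether an amine or a longer ether chain on the same aromatic carbon would stay within the scatter of compound 3. As far as these compounds go, whether chloro could stand in for the fluoro also remains open.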